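A chloro-to-fluoro exchange on compound 2

A few compounds are considered here, and "the series" means these few. Any claim that something is new, unique, unknown or untested is made for them only; others in the source may bear on it.

In an ADME assay on HepG2 2.2.15 cells (Homo sapiens) for cytotoxicity, read by CCK-8 assay, with a stated time of 8 days (a lower number here means that less compound is tolerated, a higher number that more compound is tolerated), compound 1 (`Cc1cccc(-c2cc(NC(=O)c3ccc(F)cc3O)c[nH]c2=O)c1`) gives 37200 nM and compound 2 (`CCOc1ccc(-c2cc(NC(=O)c3ccc(Cl)cc3O)c[nH]c2=O)cc1`) gives 28600 nM as its value. For the measured compounds named here, these two compounds differ in more than one place, and their numbers lie within the usual scatter of each other, so compound 2 stands level with compound 1 on the only two numbers available.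

Compound 3 (`CCOc1ccc(-c2cc(NC(=O)c3ccc(F)cc3O)c[nH]c2=O)cc1`) departs from compound 2 by a single change (fluoro in place of chloro on an aromatic carbon): fluoro in place of chloro on an aromatic carbon, meta to a hydroxy group and para to a large group. This turns 4-chloro-2-hydroxyphenyl into 4-fluoro-2-hydroxyphenyl. Going by the values given here, no pair of measured compounds shows this exchange alone, so the data give no direct size for it. Compound 1, which already carries the 4-fluoro-2-hydroxyphenyl group, reads 37200 nM and stays within the scatter of compound 2, which offers only indirect support. The estimate means a 1.1-fold higher number from compound 2 to compound 3 (0.05 log units; within the scatter) and so no expected step beyond the scatter, in either direction. In this assay compound 3 is expected at 32000 nM (range 15000 nM to 70000 nM).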

Compound 3, half-maximal cytotoxic concentration: 51500 nM
Compound 3: middle estimate off by 1.6-fold (0.21 log units), on the low side; the measured number falls inside the stated range.
By their numbers in this assay, from the lowest: compounds 2, 1 and 3 (each within the scatter of the next).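

In this assay, for the compounds shown here, with the 4-ethoxyphenyl group held fixed, fluoro in place of chloro on the aromatic carbon para to a large group gives a 1.8-fold higher number from compound 2 to compound 3 (0.26 log units; within the scatter) and so offers the first direct reading of this exchange, which shows no step beyond the scatter at this position. With the 4-fluoro-2-hydroxyphenyl group held fixed, 4-ethoxyphenyl in place of 3-methylphenyl gives a 1.4-fold higher number from compound 1 to compound 3 (0.14 log units; within the scatter) as its first direct reading, and this change likewise stays inside the scatter. Neither single change therefore separates the compounds in this assay, and nothing available accounts for the readings.

On these data alone, whether a larger or different group at the same carbon, such as bromo, trifluoromethyl, an amine or a carboxylic acid, would move the number beyond the scatter remains open. Also open, as far as these compounds go, is whether a longer chain in place of the ethoxy group would do so, and whether the chloro-to-fluoro exchange would read the same with the 3-methylphenyl group in place.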